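Octylsulfonamide benzoic acids: swapping the pendant aryl ring

The compounds below may be only part of what the source reports. "The series", "measured", "known", "first", "only" and "open" are said of these compounds alone.

Measured so far:
compound 1, `CCCCCCCCS(=O)(=O)Nc1cc(-c2ccccc2OC)ccc1C(=O)O`, 16100 nM
compound 2, `CCCCCCCCS(=O)(=O)Nc1ccc(-c2cccc(Cl)c2)cc1C(=O)O`, 8900 nM

In an assay on mitochondria (strain BALB/c) for inhibition of glycerol-3-phosphate acyltransferase 1, mitochondrial (Mus musculus), read by scintillation counting, with a stated time of 10 min (a higher number here means a weaker inhibitor, a lower number a stronger inhibitor), compound 2 gives 8900 nM, and compound 1 gives 16100 nM. The gap between the two numbers is within the usual scatter of such measurements, so compound 2 cannot be set apart from compound 1 on these two values alone.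

Compound 3, `CCCCCCCCS(=O)(=O)Nc1ccc(-c2ccc(CCCC)cc2)cc1C(=O)O`, has not yet been measured. It differs from compound 2 in one place: 4-butylphenyl in place of 3-chlorophenyl on an aromatic carbon. No step between measured compounds speaks to this kind of change, so the expectation rests only on the two numbers shown. A modest step toward a lower number in this assay is expected, possibly no larger than the scatter. Compound 3 is therefore estimated at 5500 nM, with a range from 1800 nM to 18000 nM, which would mean an expected 1.6-fold lower number from compound 2 to compound 3 (0.21 log units; within the scatter).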

Compound 3, half-maximal inhibitory concentration: 9000 nM
The estimate for compound 3 lay 1.6-fold (0.21 log units) below the measured number; low and high end bracket the measured number.
By their numbers in this assay, from the lowest: compounds 2, 3 and 1 (each within the scatter of the next).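

In this assay, putting 4-butylphenyl in place of 3-chlorophenyl, on the aromatic carbon meta to the carboxy group, gives a 1.0-fold higher number from compound 2 to compound 3 (0.00 log units; within the scatter). The incoming ring brings 10 heavy atoms and no chlorine, against 7 heavy atoms with one chlorine in the ring it replaces, yet the two compounds cannot be told apart here. At this position, then, a butyl chain at the far end of the ring serves as well as a chlorine in this assay, and no measurement on hand says why.

The compounds shown leave open whether a phenyl ring carrying an amine or a carboxylic acid at this position would shift the number, or whether a hexyl chain in place of butyl would. They also leave open whether a shorter chain than octyl on the sulfonamide would matter.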